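Piperidin-1-yl to 4-Methylpiperazin-1-yl: Compound 4 Expected

The compounds below may be only part of what the source reports. "The series", "measured", "known", "first", "only" and "open" are said of these compounds alone.

Compound 3 `COc1cc2ncnc(N3CCc4ccccc43)c2cc1NC(=O)/C=C/CN1CCCCC1` holds the lowest of the three numbers recorded in a functional assay on A549 cells (Homo sapiens) for antiproliferative activity, read by MTT assay, with a stated time of 72 h (on this read-out lower numbers stand for stronger inhibition and higher numbers for weaker inhibition), at 2540 nM. Its nearest neighbour is compound 2 `CCC/C=C/C(=O)Nc1cc2c(N3CCc4ccccc43)ncnc2cc1OC`, which gives 2920 nM; a 1.1-fold lower number from compound 2 to compound 3 (0.06 log units; within the scatter). Compound 1 `C=CC(=O)Nc1cc2c(N3CCc4ccccc43)ncnc2cc1OC` sits furthest away, at 5580 nM; a 2.2-fold lower number from compound 1 to compound 3 (0.34 log units; beyond the scatter), and a 1.9-fold lower number from compound 1 to compound 2 (0.28 log units; within the scatter). Compound 4 `COc1cc2ncnc(N3CCc4ccccc43)c2cc1NC(=O)/C=C/CN1CCN(C)CC1` differs from compound 3 by 4-methylpiperazin-1-yl in place of piperidin-1-yl on a saturated chain carbon bound to a double-bonded chain carbon. Going by the values given here, the only measured step at this place, a 1.1-fold lower number from compound 2 to compound 3 (0.06 log units; within the scatter), stayed within the scatter, and no measured pair exchanges one ring for another on this chain carbon. Compound 4 is therefore expected to show no step beyond the scatter, a 1.0-fold lower number from compound 3 to compound 4 (0.01 log units; within the scatter). Compound 4 is estimated at 2500 nM, with a range from 1200 nM to 5200 nM.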

Compound 4, half-maximal inhibitory concentration: 5360 nM
The estimate for compound 4 lay 2.1-fold (0.33 log units) below the measured number; measured number above the stated range.
By their numbers in this assay, from the lowest: compounds 3, 2, 4 and 1 (each within the scatter of the next, the first and the last beyond it).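

In this assay this chain carbon proves sensitive to the ring it carries, with a 2.1-fold higher number from compound 3 to compound 4 (0.32 log units; beyond the scatter), a modest step beyond the scatter. Compound 4 nevertheless keeps no separation from the other two compounds, with a 1.8-fold higher number from compound 2 to compound 4 (0.26 log units; within the scatter) and a 1.0-fold lower number from compound 1 to compound 4 (0.02 log units; within the scatter), both within the scatter, whereas compound 3 stood beyond the scatter from compound 1. The compounds shown offer no evidence that bears on this step. Going by these compounds, whether the ring nitrogen or its methyl governs the step remains open; piperazin-1-yl without the methyl, or morpholin-4-yl, at this place would help to separate the two.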